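Carboxymethyl on the ring nitrogen of compound 2

This account rests on a few compounds, and the source may have more. Where it says the series, first, only, none or still open, it means among the compounds named here.

Compound 1, `O=C1NC(=S)S/C1=C\c1cc2cc(Cl)ccc2nc1Cl`, was tested in a toxicity assay on PANC-1 cells (Homo sapiens) for cytotoxicity, read by MTT assay, with a stated time of 48 h; a higher number here means a weaker inhibitor of growth, a lower number a stronger inhibitor of growth. In this assay compound 1 gives > 100 ug/mL, which is a limit of the assay and not a number. Compound 2, `Cc1cccc2cc(/C=C3\SC(=S)NC3=O)c(Cl)nc12`, is a close relative of compound 1 on the shared core. In this assay compound 2 gives > 100 ug/mL, again a limit rather than a measured number. Among the measured compounds shown here, compound 2 thus stands at the limit of > 100 ug/mL in this assay, at which 2 of the 2 values shown sit; between compound 2 and compound 1 no order can be read, and the set holds no step between measured compounds from which a direction could be taken.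

Compound 3, `Cc1cccc2cc(/C=C3\SC(=S)N(CC(=O)O)C3=O)c(Cl)nc12`, differs from compound 2 by carboxymethyl in place of hydrogen on an amide-type nitrogen in a ring. With both measured values sitting at the limit, the expected step in this assay from compound 2 to compound 3 is an at least 1.2-fold lower number from compound 2 to compound 3 (0.09 log units; that floor lies within the scatter), that is, at most a modest gain that may not go beyond the usual scatter, and a further limit-only result for compound 3 remains likely. For compound 3 the estimate in this assay is 80 ug/mL, with a range from 20 ug/mL to 200 ug/mL.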

Compound 3, concentration for 50% growth inhibition: > 100 ug/mL
Compound 3: only a limit was reported (the forecaster's own chance of this, stated with the estimate: 60%); at least 1.2-fold (0.09 log units) between middle value and limit.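

Compound 3 gives > 100 ug/mL, a limit of the assay and not a number. No step from compound 2 to compound 3 can be read, so the swap of hydrogen for carboxymethyl has no readable size: the limit of > 100 ug/mL in this assay, at which 3 of the 3 values shown sit.

The compounds shown leave open where compound 1, compound 2 and compound 3 would fall as actual numbers in this assay, and whether carboxymethyl on the amide-type nitrogen in a ring changes growth inhibition at all.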